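Swapping a Sulfonyl Side Chain for a Small Ring

The source may hold more compounds than are shown below. What is called first, only, known or untested is meant among the compounds shown, and "the series" means these compounds.

Compound 1 `NS(=O)(=O)CC(=O)NCCSc1nonc1/C(=N/O)Nc1cccc(Br)c1` gives 0.918 h in an ADME assay on microsomes from liver (Mus musculus) for metabolic stability; a lower number here means that the compound disappears faster, a higher number that the compound lasts longer.
Compound 2 `NS(=O)(=O)CC(=O)NCCSc1nonc1/C(=N/O)Nc1ccc(F)c(C(F)F)c1` gives 1.07 h.
Compound 3 `CS(=O)(=O)CC(=O)NCCSc1nonc1/C(=N/O)Nc1ccc(F)c(C(F)F)c1` gives 0.765 h.

Compound 3 sits with compound 1 and compound 2 inside the usual scatter; its gaps to both are within it, so the three cannot be told apart. Compound 4 `CC1(C(=O)NCCSc2nonc2/C(=N/O)Nc2ccc(F)c(C(F)F)c2)CCN1` differs from compound 3 at one place: a group of 5 heavy atoms (4 carbon, 1 nitrogen; one four-membered non-aromatic ring with 1 hetero atom) in place of a group of 5 heavy atoms (2 carbon, 2 oxygen, 1 sulfur; no ring), on a carbonyl carbon. Going by the values given here, no measured step exchanges this whole group. The closest is the change on the sulfonyl sulfur, a 1.4-fold lower number from compound 2 to compound 3 (0.15 log units; within the scatter), which stayed within the scatter, while a 1.2-fold higher number from compound 1 to compound 2 (0.07 log units; within the scatter) concerns a different part of the molecule. The present change is larger than either, so a shift beyond the scatter cannot be excluded, but the data give no direction for it. Compound 4 is therefore estimated at 0.8 h, between 0.4 h and 1.6 h. The expected step is a 1.0-fold higher number from compound 3 to compound 4 (0.02 log units; within the scatter).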

Compound 4, half-life: 0.268 h
For compound 4 the middle estimate is 3.0-fold (0.47 log units) above the measured one; the whole stated range lies above it.
By their numbers in this assay, from the lowest: compound 4; then compounds 3, 1 and 2 (each within the scatter of the next).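

Replacing the whole (methylsulfonyl)methyl on the carbonyl carbon with the four-membered ring gives a 2.9-fold lower number from compound 3 to compound 4 (0.46 log units; beyond the scatter) in this assay, so this position responds where the earlier changes stayed within the scatter. The amino-bearing sulfonyl side chain points the same way, with a 4.0-fold lower number from compound 2 to compound 4 (0.60 log units; beyond the scatter) as the step to the ring. No measured finding explains this drop.

Going by these compounds, whether the ring itself, its methyl or its nitrogen matters remains open. An open-chain amine or a carboxylic acid on the same carbonyl carbon would help separate these possibilities.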